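This account rests on a few compounds, and the source may have more. Where it says the series, first, only, none or still open, it means among the compounds named here.

Compound 1 `CCC#C[C@@]1(O)[C@@H](CO)O[C@@H](n2ccc(N)nc2=O)[C@@H]1O` and compound 2 `C=C[C@@]1(O)[C@@H](CO)O[C@@H](n2ccc(N)nc2=O)[C@@H]1O` share one core and differ in a single place: vinyl in place of but-1-yn-1-yl on a saturated ring carbon. In a functional assay on L1210 cells (Mus musculus), read by MTT assay (a lower number here means a stronger inhibitor, a higher number a weaker inhibitor), compound 1 gives 129000 nM, and compound 2 gives 60800 nM; the step is a 2.1-fold lower number from compound 1 to compound 2 (0.33 log units; beyond the scatter). Compound 3 `CCC#C[C@@]1(O)[C@@H](CO)O[C@@H](n2ccc(=O)[nH]c2=O)[C@@H]1O` carries the but-1-yn-1-yl group on a second core; how the two cores differ is not broken down here. In this assay compound 3 gives 338000 nM, the highest number of the three. Compound 4 `C=C[C@@]1(O)[C@@H](CO)O[C@@H](n2ccc(=O)[nH]c2=O)[C@@H]1O` is not yet measured and differs from compound 3 by the same kind of change: vinyl in place of but-1-yn-1-yl on a saturated ring carbon. Going by the values given here, a step of similar size is expected because the only precedent is a 2.1-fold lower number from compound 1 to compound 2 (0.33 log units; beyond the scatter), resting on one pair alone. Compound 4 is therefore estimated at 160000 nM, within 70000 nM to 360000 nM. The expected step is a 2.1-fold lower number from compound 3 to compound 4 (0.32 log units; beyond the scatter).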

Compound 4, half-maximal inhibitory concentration: 148000 nM
The estimate for compound 4 lay 1.1-fold (0.03 log units) above the measured number, and the stated range covers the measured number.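

In this assay, vinyl in place of but-1-yn-1-yl gives a 2.3-fold lower number from compound 3 to compound 4 (0.36 log units; beyond the scatter), and the size of the step carries over from one core to the other: the same change on two cores in this assay, a 2.1-fold lower number (0.33 log units; beyond the scatter) from compound 1 to compound 2 and a 2.3-fold lower number (0.36 log units; beyond the scatter) from compound 3 to compound 4, 1.1-fold (0.03 log units) apart, within the scatter of two such steps

This agreement rests on two pairs in a single assay, so it supports carrying the change only between the core of compound 1 and the core of compound 3. It does not show that the step would hold on any further core or in any other assay, and it does not explain the step.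

The compounds shown leave open how an ethyl group, an aminomethyl group or a longer alkyne chain on the same saturated ring carbon would compare with vinyl and but-1-yn-1-yl.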